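The source may report more compounds than this note shows. Statements on the series, on what has been measured and on what is new or still open speak of the compounds shown alone.

Measured in a physicochemical assay for solubility, in phosphate buffer, with a stated time of 18 h, at pH 7.4; a lower number here means a less soluble compound, a higher number a more soluble compound:
Compound 1 `COc1cc2ncnc(-n3nc(-c4ccccn4)nc3N)c2cc1[N+](=O)[O-]` gives 2000 nM
Compound 2 `COc1cc2ncnc(-n3nc(-c4ccccn4)nc3N)c2cc1OCCCN(C)C` gives 53000 nM
Compound 3 `CCN(CC)C(=O)COc1cc2c(-n3nc(-c4ccccn4)nc3N)ncnc2cc1OC` gives 42000 nM

Compound 2 sits at the upper end of these three numbers, but not alone, since its nearest neighbour lies within the scatter (the step is a 1.3-fold lower number from compound 2 to compound 3 (0.10 log units; within the scatter)). The distance to the lower end is much larger (the steps are a 27-fold higher number from compound 1 to compound 2 (1.42 log units; beyond the scatter) and a 21-fold higher number from compound 1 to compound 3 (1.32 log units; beyond the scatter)).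

Compound 4 `COc1cc2ncnc(-n3nc(-c4ccccn4)nc3N)c2cc1OCCCNC(=O)CN1C[C@@H](C)O[C@@H](C)C1` keeps the core and the propoxy chain of compound 2 and differs at the end of the chain ((((2,6-dimethylmorpholin-4-yl)methyl)carbonyl)amino in place of dimethylamino on a saturated chain carbon, three bonds along the chain from an oxygen on an aromatic ring). In words, this is (((2,6-dimethylmorpholin-4-yl)methyl)carbonyl)amino in place of dimethylamino on a saturated chain carbon, three bonds along the chain from an oxygen on an aromatic ring.

Among the compounds with values here, no measured step makes this exact change. The two large steps replace nitro, so they say little here. The nearest guide is the change of side chain in a 1.3-fold lower number from compound 2 to compound 3 (0.10 log units; within the scatter), which stayed within the scatter. A small move to a lower number is therefore expected, close to the edge of the scatter.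

The expected size of the change is an estimated 1.8-fold lower number from compound 2 to compound 4 (0.25 log units; within the scatter).

For compound 4 the estimate is 30000 nM, with an expected range from 10000 nM to 80000 nM.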

Compound 4, solubility: 34000 nM
Beside the measured number, compound 4's estimate is 1.1-fold (0.05 log units) below it, and the stated range covers the measured number.
By their numbers in this assay, from the lowest: compound 1; then compounds 4, 3 and 2 (each within the scatter of the next).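

In this assay, the end of the propoxy chain takes a far bigger group without a change beyond the scatter: (((2,6-dimethylmorpholin-4-yl)methyl)carbonyl)amino, with 12 heavy atoms against 3 in dimethylamino, gives a 1.6-fold lower number from compound 2 to compound 4 (0.19 log units; within the scatter). The earlier side-chain step had replaced the chain end together with part of the chain, whereas this one keeps the propoxy chain and shows that a six-membered non-aromatic ring, a carbonyl, a hydrogen-bond donor and 2 defined stereocentres can all enter at that end while the number stays within the scatter of compound 2. Nothing measured here explains why the number holds.

The compounds shown leave open whether a carboxylic acid at the end of the chain would also stay within the scatter of compound 2. The same question stands for a longer chain carrying dimethylamino, and for plain morpholine without its two methyl groups.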